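Removing a Chloro Group from a Benzyl Amide

The source may report more compounds than this note shows. Statements on the series, on what has been measured and on what is new or still open speak of the compounds shown alone.

Compound 3 `CC(Sc1nnc(-c2ccncc2)s1)C(=O)NCc1ccc(Cl)cc1` carries a 4-chlorobenzyl group on its amide nitrogen. In an ADME assay on HepG2 cells (Homo sapiens) for cytotoxicity, with a stated time of 3 days (a higher number here means that more compound is tolerated, a lower number that less compound is tolerated), compound 3 gives "not determined" (no result reported), so there is no number on which to place it. Its two closest relatives do have entries. Compound 1 `CC(Sc1nnc(-c2ccncc2)s1)C(=O)Nc1ccc(Cl)cc1Cl` carries a 2,4-dichlorophenyl group at the same position. In this assay compound 1 gives > 50000 nM, which is a limit of the assay and not a number. Compound 2 `CC(Sc1nnc(-c2ccncc2)s1)C(=O)NCc1ccccc1Cl` carries a 2-chlorobenzyl group in that place. In this assay compound 2 gives > 50000 nM, again a limit of the assay. The step that the two limits leave unreadable from compound 1 to compound 2 therefore cannot be read. Both reported entries sit at the limit of > 50000 nM in this assay, at which 2 of the 3 values shown sit.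

Compound 4 `CC(Sc1nnc(-c2ccncc2)s1)C(=O)NCc1ccccc1` differs from compound 3 by hydrogen in place of chloro on an aromatic carbon. Among the measured compounds shown here, no measured step bears on this change, and compound 3 itself has no number, so nothing measured sets the size or direction of the step. For the measured compounds named here, the only guidance is that both reported values for this shared core rest at the limit, so no step beyond the scatter is expected in this assay for compound 4. Compound 4 is expected to give about 50000 nM in this assay, with a range from 20000 nM to 200000 nM, and most likely reported only as a limit.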

Compound 4, half-maximal cytotoxic concentration: > 50000 nM
Compound 4: only a limit was reported; the forecaster's own chance of this, stated with the estimate: 75%; the middle value lies on the limit itself.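

In this assay compound 4 gives > 50000 nM, which is a limit of the assay and not a number. Its steps from compound 1 and compound 2 therefore cannot be read, and the reported entries share one limit: the limit of > 50000 nM in this assay, at which 3 of the 4 values shown sit.

The compounds shown leave open where any of them would reach a half-maximal cytotoxic concentration, and what hydrogen in place of chloro does to compound 3.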